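The compounds below may be only part of what the source reports. "The series", "measured", "known", "first", "only" and "open" are said of these compounds alone.

Measured in an assay on membranes from CHO cells for displacement of a labelled ligand from adenosine receptor A1 (Homo sapiens), read by scintillation counting, with a stated time of 60 min, tested at 1 uM; a higher number here means more inhibition at the concentration tested (going by the name of the read-out), a lower number less inhibition:
compound 1 `CC1=C(C(=O)SC(C)C)C(c2ccco2)NC(=O)N1` gives 5%
compound 2 `CC1=C(C(=O)OC2CCC2)C(c2ccco2)NC(=O)N1` gives 19%

Going by the values given here, compound 2 holds the higher of the two numbers; the only measured step, a number 14 percentage points higher from compound 1 to compound 2 (beyond the scatter), is the change from isopropylsulfanyl to cyclobutyloxy on a carbonyl carbon. Compound 3 `CC1=C(C(=O)OCC2CCC2)C(c2ccco2)NC(=O)N1` differs from compound 2 in one place: cyclobutylmethyl in place of cyclobutyl on an oxygen next to a carbonyl group. Among the compounds with values here, no measured step alters the group on the oxygen next to a carbonyl group while keeping that oxygen, so the step from compound 1 to compound 2 shows only that this part of the molecule can move the read-out in this assay. Compound 3 is therefore expected to stay near compound 2, with an estimated step of a number 1 percentage points higher from compound 2 to compound 3 (within the scatter). The estimate for compound 3 is 20%, expected to fall between 5% and 40%.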

Compound 3, a percentage reported as inhibition, at one concentration (the size of the read-out at that concentration, not a potency): 42%
Beside the measured number, compound 3's estimate is 22 percentage points below it, and the stated range ends below it.
By their numbers in this assay, from the lowest: compound 1; then compound 2; then compound 3.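

In this assay, cyclobutylmethyl in place of cyclobutyl on an oxygen next to a carbonyl group gives a number 23 percentage points higher from compound 2 to compound 3 (beyond the scatter), so the group on that oxygen moves the read-out even with the oxygen itself kept. The wider change, cyclobutylmethoxy in place of isopropylsulfanyl on a carbonyl carbon, gives a number 37 percentage points higher from compound 1 to compound 3 (beyond the scatter). No evidence at hand bears on the reason for these differences.

The compounds shown leave open whether a longer chain on that oxygen would raise the number further or lower it. They also leave open how an amine or a carboxylic acid on that chain would read.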